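Swapping a Propyl Amide for an Aryl Amide

The source may hold more compounds than are shown below. What is called first, only, known or untested is meant among the compounds shown, and "the series" means these compounds.

Compound 1, `C=CC1=C(C(=O)NCCC)C(c2ccc(F)cc2)OC1`: > 100000 nM
Compound 2, `C=CC1=C(C(=O)NC(C)(C)C)C(c2ccc(Cl)c(Cl)c2)OC1`: > 100000 nM

Both measured compounds share the core of compound 1 and differ in the group on the amide nitrogen and in the halogens on the pendant ring. In a functional assay on SW480 cells (Homo sapiens) for cytotoxicity, read by MTT assay, with a stated time of 24 h (a higher number here means a weaker inhibitor, a lower number a stronger inhibitor), compound 1 gives > 100000 nM, which is a limit of the assay rather than a number. Compound 2 likewise gives > 100000 nM in this assay, again a limit. For the measured compounds named here, every value shown so far therefore sits at the limit of > 100000 nM in this assay, at which 2 of the 2 values shown sit, so compound 1 stands at the limit together with the only other compound measured, and no step between measured compounds can be read.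

Compound 3, `C=CC1=C(C(=O)Nc2cccc(C)c2)C(c2ccc(F)cc2)OC1`, is the next candidate. It differs from compound 1 by 3-methylphenyl in place of propyl on an amide-type nitrogen. With neither measured compound showing any activity, the expected step that the limit leaves unreadable from compound 1 to compound 3 is none beyond the scatter. Compound 3 is therefore expected to give 150000 nM, somewhere between 50000 nM and 400000 nM, and most likely to be reported only as a limit once more.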

Compound 3, half-maximal inhibitory concentration: > 100000 nM
Compound 3 ended at the assay's limit; the forecaster's own chance of this, stated with the estimate: 75%; the middle value does not contradict the limit.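

No step can be read from compound 1 to compound 3, since both stand at a limit in this assay: the limit of > 100000 nM in this assay, at which 3 of the 3 values shown sit.

The compounds shown leave open whether any other group on the amide nitrogen, or any other change to the shared core, would give a true number in this assay.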